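This account rests on a few compounds, and the source may have more. Where it says the series, first, only, none or still open, it means among the compounds named here.

Compound 1 `CCC(=O)Nc1cccc(Oc2nc(Nc3ccc(N4CCN(C)CC4)cc3)ncc2Cl)c1` and compound 2 `CCC(=O)Nc1cccc(Oc2ccnc(Nc3ccc(N4CCN(C)CC4)cc3)n2)c1` were both tested in an assay on isolated protein for inhibition of NUAK family SNF1-like kinase 1 (Homo sapiens), read by ADP-Glo, with a stated time of 60 min, tested at 10 uM, in the presence of a further agent that is not named here; a higher number here means more inhibition at the concentration tested (going by the name of the read-out), a lower number less inhibition. In that assay compound 1 gives 92.9% and compound 2 gives 85.6%; compound 1 holds the higher of these two numbers, but the step of a number 7.3 percentage points lower from compound 1 to compound 2 (within the scatter) lies within the scatter, so the two cannot be ordered.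

Compound 3 `CCC(=O)Nc1cccc(Oc2nc(Nc3ccc(N4CCC(C)CC4)cc3)ncc2Cl)c1` has not been measured. It differs from compound 1 in one place: 4-methylpiperidin-1-yl in place of 4-methylpiperazin-1-yl on an aromatic carbon. For the measured compounds named here, the only measured step, from compound 1 to compound 2, concerns a different place, the exchange of chloro for hydrogen, and it was within the scatter; no measured step touches the ring that is exchanged here. With nothing to point to a direction, and both measured values high, compound 3 is expected to stay near compound 1, at about 82%, between 60% and 96%, an estimated step of a number 10.9 percentage points lower from compound 1 to compound 3 (beyond the scatter).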

Compound 3, a percentage reported as inhibition, at one concentration (the size of the read-out at that concentration, not a potency): 13.4%
The estimate for compound 3 lay 68.6 percentage points above the measured number; the measured number lies below the stated range.
By their numbers in this assay, from the lowest: compound 3; then compounds 2 and 1 (each within the scatter of the next).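

In this assay the exchange at this place gives a number 79.5 percentage points lower from compound 1 to compound 3 (beyond the scatter) and stands in contrast to the swap of chloro for hydrogen, which gave a number 7.3 percentage points lower from compound 1 to compound 2 (within the scatter) and so showed nothing that could be ordered. The two groups have the same number of heavy atoms, and the change amounts to one ring nitrogen replaced by carbon, with one hydrogen-bond acceptor fewer, so in this pair a single-atom exchange on an otherwise unchanged compound is enough for a large step. Nothing measured here says why this exchange has such an effect.

The compounds shown leave open how other groups at this place would read, such as morpholin-4-yl, piperazin-1-yl without the methyl, or a dimethylamino group. They also leave open whether the same exchange would give a step of similar size on compound 2, which carries hydrogen in place of chloro.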